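Dichlorophenyl to cyanophenyl on the oxadiazole-linked aryl group

The compounds below may be only part of what the source reports. "The series", "measured", "known", "first", "only" and "open" are said of these compounds alone.

Three members of the series have been measured in a functional assay on mitochondria from heart for inhibition of peroxisomal acyl-coenzyme A oxidase 1 (Rattus norvegicus); a higher number here means a weaker inhibitor, a lower number a stronger inhibitor. Compound 1 `Cc1nc2cc(OC[C@H](O)CN3CCN(Cc4nc(-c5ccc(C(F)(F)F)cc5)no4)CC3)ccc2s1` gives 3630 nM. Compound 2 `Cc1nc2cc(OC[C@H](O)CN3CCN(Cc4coc(-c5ccc(C(F)(F)F)cc5)n4)CC3)ccc2s1` gives 11000 nM. Compound 3 `Cc1nc2cc(OC[C@H](O)CN3CCN(Cc4noc(-c5ccc(Cl)c(Cl)c5)n4)CC3)ccc2s1` gives 550 nM, the lowest number of the three; its gap to compound 1 and its gap to compound 2 both lie beyond the usual scatter, so compound 3 is the strongest inhibitor among the measured compounds. No single-point change between any two of these three has been measured, so no step size within the series is known directly.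

Compound 4 `Cc1nc2cc(OC[C@H](O)CN3CCN(Cc4noc(-c5cccc(C#N)c5)n4)CC3)ccc2s1` has not yet been measured in this assay. It differs from compound 3 in one place: 3-cyanophenyl in place of 3,4-dichlorophenyl on an aromatic carbon. Going by the values given here, with no measured step of the same kind, the expectation rests only on the values shown. The other two aryl variants, compound 1 and compound 2, carry higher numbers than compound 3, and a change away from the 3,4-dichlorophenyl of compound 3 is expected to move the number upward, toward a weaker inhibitor, beyond the scatter. The expected step is a 5.5-fold higher number from compound 3 to compound 4 (0.74 log units; beyond the scatter). For compound 4 the estimated value is 3000 nM, with a range from 800 nM to 12000 nM.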

Compound 4, half-maximal inhibitory concentration: 13400 nM
Compound 4: middle estimate off by 4.5-fold (0.65 log units), on the low side; the whole stated range lies below it.
By their numbers in this assay, from the lowest: compound 3; then compound 1; then compounds 2 and 4 (each within the scatter of the next).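

Going by these compounds alone, this is the first single-place step: in this assay, 3-cyanophenyl in place of 3,4-dichlorophenyl gives a 24-fold higher number from compound 3 to compound 4 (1.39 log units; beyond the scatter), a large loss of inhibition, at the aromatic carbon of the five-membered aromatic ring with 2 nitrogen and 1 oxygen. The read-out is therefore highly sensitive to the aryl group at this position, even though the two groups have the same heavy-atom count and each holds one six-membered aromatic ring of carbon only; the swap removes both chlorines and brings in a nitrile, with its triple bond and hydrogen-bond acceptor. Nothing measured here explains the size of this step.

The compounds shown leave open whether the loss follows from the departure of the chlorines or the arrival of the nitrile, a question that a plain phenyl or a 3-chlorophenyl at the same carbon would help to separate. Also open, going by these compounds, is how this position responds to a 3-aminophenyl or to a phenyl bearing a carboxylic acid, on the same shared core.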